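Inverting a Ring Stereocentre in a Hydroxyproline Amide

The source may report more compounds than this note shows. Statements on the series, on what has been measured and on what is new or still open speak of the compounds shown alone.

Compound 2 `O=C(O)[C@@H](CO)NC(=O)[C@H]1C[C@@H](O)CN1` is the higher of the two compounds measured in an ADME assay on the whole organism (Mus musculus, strain C57BL/6) for pharmacokinetics, read by HPLC, with a stated time of 6 h, at a dose of 25 mg/kg by the oral route (a higher number here means more compound in the circulation at the dose given, a lower number less compound in the circulation), where compound 2 gives 24000 nM. Compound 1 `O=C(N[C@H](CO)C(=O)O)[C@@H]1C[C@@H](O)CN1` has the same atoms and bonds, and in this assay compound 1 gives 640 nM. The step of a 38-fold higher number from compound 1 to compound 2 (1.57 log units; beyond the scatter) is traced to the fact that compounds 1 and 2 differ only in the configuration as drawn. Compound 3 `O=C(O)[C@@H](CO)NC(=O)[C@H]1C[C@H](O)CN1` is the next compound, not yet measured. The change from compound 2 to compound 3 is the two compounds have the same atoms and bonds and differ only in configuration as drawn: 1 of 3 stereo elements differ; a stereocentre at a saturated ring carbon is drawn R in compound 2 and S in compound 3. Among the measured compounds shown here, the only measured step, a 38-fold higher number from compound 1 to compound 2 (1.57 log units; beyond the scatter), is a change of the same kind, a single ring stereocentre inverted, and it was large. That step shows such a change can move the number far in either direction, so a step beyond the scatter is expected for compound 3, with the direction uncertain. Compound 3 is expected to give 8000 nM, within 1500 nM to 40000 nM, a step of a 3.0-fold lower number from compound 2 to compound 3 (0.48 log units; beyond the scatter).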

Compound 3, maximal plasma concentration: 22900 nM
The estimate for compound 3 lay 2.9-fold (0.46 log units) below the measured number; the range from low to high includes it.
By their numbers in this assay, from the lowest: compound 1; then compounds 3 and 2 (each within the scatter of the next).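

In this assay, the ring stereocentre inverted here behaves unlike the one inverted earlier, giving a 1.0-fold lower number from compound 2 to compound 3 (0.02 log units; within the scatter), so the drawn configuration at this carbon makes no difference that can be told from the scatter. Sensitivity to configuration in this series therefore depends on which ring stereocentre changes, since the earlier inversion gave the large step of a 38-fold higher number from compound 1 to compound 2 (1.57 log units; beyond the scatter). The pair differing at both ring stereocentres fits this reading, with a 36-fold higher number from compound 1 to compound 3 (1.55 log units; beyond the scatter), a large step even with the second centre also inverted.

The compounds shown do not tell why one stereocentre matters and the other does not, nor whether the second centre would remain silent with the first centre in its other configuration. They also leave open whether an amine or a methoxy group in place of the ring hydroxyl would give a similar number.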